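Five- to six-membered ring swap in a promoter series

The source may hold more compounds than are shown below. What is called first, only, known or untested is meant among the compounds shown, and "the series" means these compounds.

Compound 1 `CC[N+]1(CCCCCCCOc2ccc(-n3cc(C(=O)Nc4cc(F)cc(F)c4)c(=O)c4ccc(N(C)C)nc43)cc2Cl)CCCC1` and compound 3 `CN(C)c1ccc2c(=O)c(C(=O)Nc3cc(F)cc(F)c3)cn(-c3ccc(OCCCCCCC[N+](C)(C)C4CCCCC4)c(Cl)c3)c2n1` share one core; compound 2 `CC[N+]1(CCCCCCCOc2cc(-n3cc(C(=O)Nc4cc(F)cc(F)c4)c(=O)c4ccc(N(C)C)nc43)ccc2C)CCCC1` and compound 4 `Cc1ccc(-n2cc(C(=O)Nc3cc(F)cc(F)c3)c(=O)c3ccc(N(C)C)nc32)cc1OCCCCCCC[N+](C)(C)C1CCCCC1` share another, and the difference between the two cores is not broken down here. All three measured compounds were run in an assay on LX2 cells for inhibition of COL1A1 promoter (Homo sapiens), read by a luciferase reporter, with a stated time of 24 h, tested at 50 uM; on this read-out lower numbers stand for a weaker effect and higher numbers for a stronger effect at the one concentration tested. In this assay compound 1 gives 23.5%, compound 3 gives 86.2% and compound 2 gives 81.4%. The values of compound 2 and compound 3 lie within the scatter of each other.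

Within the data shown here, the one counted change on the first core is a group of 9 heavy atoms (8 carbon, 1 nitrogen; one six-membered non-aromatic ring of carbon only) in place of a group of 7 heavy atoms (6 carbon, 1 nitrogen; one five-membered non-aromatic ring with 1 hetero atom), on a saturated chain carbon, seven bonds along the chain from an oxygen on an aromatic ring. It made a number 62.7 percentage points higher from compound 1 to compound 3 (beyond the scatter). On the second core the change is a group of 9 heavy atoms (8 carbon, 1 nitrogen; one six-membered non-aromatic ring of carbon only) in place of a group of 7 heavy atoms (6 carbon, 1 nitrogen; one five-membered non-aromatic ring with 1 hetero atom), on a saturated chain carbon, seven bonds along the chain from an oxygen on an aromatic ring. The place is the same in both cases word for word, so this is the same change, not merely the same kind.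

Compound 2 already sits near the top of the percentage scale, and the read-out is a fraction at a single concentration, so the room above it is limited. The step from compound 2 to compound 4 is therefore expected to be far smaller than the earlier one, estimated as a number 8.6 percentage points higher from compound 2 to compound 4 (within the scatter). This rests on compound 2 starting from 81.4%, whereas the large earlier step began from the low figure of compound 1 at 23.5%. Compound 4 is estimated to give 90% in this assay, with a range from 78% to 98%.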

Compound 4, a percentage reported as inhibition, at one concentration (the size of the read-out at that concentration, not a potency): 61.7%
Beside the measured number, compound 4's estimate is 28.3 percentage points above it, outside the stated range (below it).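

In this assay the six-membered carbon ring group in place of the five-membered ring group gives a number 19.7 percentage points lower from compound 2 to compound 4 (beyond the scatter), so the same change does not carry from one core to the other, in either size or direction: the same change on two cores in this assay, a number 62.7 percentage points higher (beyond the scatter) from compound 1 to compound 3 and a number 19.7 percentage points lower (beyond the scatter) from compound 2 to compound 4, 82.4 percentage points apart, beyond the scatter of two such steps

On these two pairs, the outcome of this change depends on the core that carries it, and a step read on the core of compound 1 gives no safe forecast for the core of compound 2. Among these compounds, what remains unshown is which feature of the two cores separates the steps, and how the steps would look at any other concentration, as each value gives the size of the effect at one concentration only and only two pairs are available.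

Open, on these data alone, is whether an ethyl piperidinium or a trimethylammonium group, in place of either ring group, would follow the step seen on the core of compound 1 or that seen on the core of compound 2. Also open, as far as these compounds go, is whether a shorter or longer chain would keep the two steps apart, and whether a third core would side with either of them.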